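This account rests on a few compounds, and the source may have more. Where it says the series, first, only, none or still open, it means among the compounds named here.

In an ADME assay on HepG2 cells (Homo sapiens) for cytotoxicity, read by resazurin assay, with a stated time of 24 h (a lower number here means that less compound is tolerated, a higher number that more compound is tolerated), compound 2 `Cc1cc(O)c(C(=O)O)c(C=Cc2ccc3ccccc3c2)c1` gives 30000 nM, at the low end of the three numbers measured. Compound 1 `CCN(CC)C(=O)c1c(CCc2ccc3ccccc3c2)cccc1OC` gives 35800 nM, which lies within the scatter of compound 2, while compound 3 `COc1cc(O)c(C(=O)O)c(C=Cc2ccc3ccccc3c2)c1` gives 79000 nM, and the step of a 2.6-fold higher number from compound 2 to compound 3 (0.42 log units; beyond the scatter) is the only one beyond the scatter. Compound 4 `COc1cc(C)cc(C=Cc2ccc3ccccc3c2)c1C(=O)O` has not yet been measured; it differs from compound 2 by methyl in place of hydrogen on an oxygen on an aromatic ring. Going by the values given here, no measured step carries this exact change; the step of a 2.6-fold higher number from compound 2 to compound 3 (0.42 log units; beyond the scatter) also brings in a methoxy and moved the number modestly upward. A step of similar or smaller size with no firm direction is therefore expected, and compound 4 is estimated at 40000 nM, between 18000 nM and 90000 nM, meaning a 1.3-fold higher number from compound 2 to compound 4 (0.12 log units; within the scatter).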

Compound 4, half-maximal cytotoxic concentration: 117000 nM
Estimate against measurement, compound 4: 2.9-fold (0.47 log units) below, and the stated range ends below it.
By their numbers in this assay, from the lowest: compounds 2 and 1 (each within the scatter of the next); then compounds 3 and 4 (each within the scatter of the next).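

In this assay, a 3.9-fold higher number from compound 2 to compound 4 (0.59 log units; beyond the scatter) shows that a single methyl on this oxygen, turning hydroxy to methoxy, moves the number beyond the scatter. Alongside a 2.6-fold higher number from compound 2 to compound 3 (0.42 log units; beyond the scatter), it gives two single changes to compound 2 that bring in a methoxy at different places, and both raise the number. Nothing available explains this rise. Open, from the compounds shown here alone, is whether a longer chain on this oxygen would raise the number further or reverse the step. Also open, going by these compounds, is how an amine at this place would compare.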